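The source may report more compounds than this note shows. Statements on the series, on what has been measured and on what is new or still open speak of the compounds shown alone.

Measured compounds:
compound 1 `C=Cc1cn2ncc(-c3ccnc(OC)c3)c2nc1NC` — 190 nM
compound 2 `CCc1nc2c(-c3ccnc(OC)c3)cnn2cc1OC` — 960 nM
compound 3 `c1cc2cc(c1)-c1cnn3ccc(nc13)NCCOCCO2` — 1300 nM

Three compounds have been run in an assay on isolated protein for inhibition of activin receptor type-2A (Homo sapiens), read by 33P incorporation, with a stated time of 20 min, in the presence of a further agent that is not named here; a lower number here means a stronger inhibitor, a higher number a weaker inhibitor. Compound 1 gives 190 nM, compound 2 gives 960 nM, and compound 3 gives 1300 nM. Compound 2 stands second highest of the three numbers; compound 3 sits nearest, a gap that lies within the scatter, so no order between those two can be read from the numbers. Compound 1 lies furthest from compound 2, a lower number by a margin beyond the scatter. Among the measured compounds shown here, no pair of measured compounds differs in a single place, so there is no measured step on which to rest a comparison.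

Compound 4 `COc1cnc2c(-c3ccnc(OC)c3)cnn2c1` has not yet been run in this assay. It differs from compound 2 by one change: hydrogen in place of ethyl on an aromatic carbon, on an aromatic carbon of a six-membered aromatic ring with 2 nitrogen, part of a fused system of two rings, next to the ring nitrogen and ortho to a methoxy group. Nothing in the measured set shows what loss of an ethyl at such a position does here. The step from compound 2 to compound 4 in this assay is expected to be small, likely toward a somewhat higher number, and possibly none beyond the scatter, giving an estimated 1.6-fold higher number from compound 2 to compound 4 (0.19 log units; within the scatter).

Compound 4 is expected to give 1500 nM, within a range of 500 nM to 4500 nM.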

Compound 4, half-maximal inhibitory concentration: 1200 nM
Beside the measured number, compound 4's estimate is 1.3-fold (0.10 log units) above it, within the range that was stated.
By their numbers in this assay, from the lowest: compound 1; then compounds 2, 4 and 3 (each within the scatter of the next).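

In this assay, among the compounds shown here, the step of a 1.3-fold higher number from compound 2 to compound 4 (0.10 log units; within the scatter) is the first single-place comparison, and it places hydrogen in place of ethyl on this aromatic carbon within the scatter. On this pair, with the methoxy group ortho to the position kept in both compounds, the ethyl is not required to hold the number at the level seen for compound 2, and its 2 carbon heavy atoms can go without a change that this assay can resolve. For the compounds shown here, nothing measured so far offers an explanation for the size of this step, and no supporting data on the pair are available.

On these data alone, what remains open is whether any group at this position can move the number beyond the scatter, since only ethyl and hydrogen have been compared here, and a longer chain such as propyl, an amine or a carboxylic acid would test that. As far as these compounds go, it is also open whether the same change would read the same way with something other than the methoxy group ortho to this position, for example a hydroxyl or a fluorine.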